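This account rests on a few compounds, and the source may have more. Where it says the series, first, only, none or still open, it means among the compounds named here.

Working notes on the series, measured in a functional assay on MCF7 cells (Homo sapiens) for antiproliferative activity, read by MTT assay, with a stated time of 48 h; on this read-out higher numbers stand for weaker inhibition and lower numbers for stronger inhibition:

- compound 1 `COc1ccc(/C=C/C(=O)Nc2cc(-c3ccc(Br)cc3)[nH]n2)cc1`: 590 nM
- compound 2 `O=C(/C=C/c1ccc(Br)cc1)Nc1cc(-c2ccc(Br)cc2)[nH]n1`: 920 nM
- compound 3 `O=C(/C=C/c1ccc([N+](=O)[O-])cc1)Nc1cc(-c2ccccc2)[nH]n1`: 630 nM

Compound 2, at 920 nM, lies within the scatter of both compound 1 and compound 3, so the numbers do not separate it from either.

The next compound to be read is compound 4 `O=C(/C=C/c1ccccc1)Nc1cc(-c2ccc(Br)cc2)[nH]n1`. Its difference from compound 2 is hydrogen in place of bromo on an aromatic carbon, para to a large group.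

For the measured compounds named here, one measured step bears on this, and it concerns the same place on the same ring: a 1.6-fold higher number from compound 1 to compound 2 (0.19 log units; within the scatter). That exchange of methoxy for bromo did not move the number beyond the scatter. Going by the values given here, no measured pair shows hydrogen at this place, so the expectation is an extrapolation from that single step. Compound 2 differs from compound 3 in more than one place, so compound 3, at 630 nM, offers only a general level.

No step beyond the scatter is expected in this assay. The expected change is a 1.2-fold lower number from compound 2 to compound 4 (0.09 log units; within the scatter), and its direction is not firmly supported by the data. The estimated value for compound 4 is 750 nM, with an expected range of 300 nM to 1900 nM.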

Compound 4, half-maximal inhibitory concentration: 1120 nM
Beside the measured number, compound 4's estimate is 1.5-fold (0.17 log units) below it, within the range that was stated.
By their numbers in this assay, from the lowest: compounds 1, 3, 2 and 4 (each within the scatter of the next).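

In this assay, the reading gives the first view of this place with no substituent at all, and the exchange of bromo for hydrogen gives a 1.2-fold higher number from compound 2 to compound 4 (0.09 log units; within the scatter). Set against methoxy at the same place, hydrogen gives a 1.9-fold higher number from compound 1 to compound 4 (0.28 log units; within the scatter), so with the 4-bromophenyl group held on the other side of the amide, methoxy, bromo and hydrogen on this aromatic carbon are not separated by the numbers, and an unsubstituted phenyl here does not take the read-out beyond the scatter of either substituted compound. No supporting measurement bears on why these three numbers lie together.

Still open, going by these compounds, is whether a group of another kind at this place, such as an amine, a carboxylic acid or a longer alkoxy chain, would give a step beyond the scatter, since the three groups read so far do not. On these data alone, compound 3 differs from each of the others in more than one place, so its nitro group cannot be read against them, and whether this flat picture holds with a phenyl in place of the 4-bromophenyl group on the other side also remains open.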